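Swapping Isopropylamino for Ethyl(methyl)amino on a Fused Core

This account rests on a few compounds, and the source may have more. Where it says the series, first, only, none or still open, it means among the compounds named here.

Compound 1, `CNc1ncnc2c1ncn2Cc1c(F)cccc1F`, gives 2 mg/kg in a functional assay on the whole organism with Rattus norvegicus as the target, in the maximal electroshock model; a lower number here means that less compound is needed, a higher number that more compound is needed for the effect.
Compound 2, `CC(C)Nc1ncnc2c1ncn2Cc1ccccc1F`, gives 5.8 mg/kg in this assay.

Compound 2 has the highest of the two numbers; compound 1 lies a fair way lower, beyond the usual scatter. Compound 3, `CCN(C)c1ncnc2c1ncn2Cc1ccccc1F`, carries ethyl(methyl)amino in place of isopropylamino on an aromatic carbon. The two have the same atoms joined differently, and the change removes the hydrogen-bond donor. Within the data shown here, no measured pair shows this kind of change, so the expectation is a modest step upward in the dose, possibly none beyond the scatter, with the step from compound 2 to compound 3 estimated as a 1.4-fold higher number from compound 2 to compound 3 (0.14 log units; within the scatter). For compound 3 the expected value is 8 mg/kg, with a range from 3 mg/kg to 25 mg/kg.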

Compound 3, dose for half-maximal effect: 2.9 mg/kg
For compound 3 the middle estimate is 2.8-fold (0.44 log units) above the measured one, outside the stated range (below it).
By their numbers in this assay, from the lowest: compounds 1, 3 and 2 (each within the scatter of the next, the first and the last beyond it).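

On this aromatic carbon, ethyl(methyl)amino takes the place of isopropylamino and the hydrogen-bond donor is lost, yet this assay shows only a 2.0-fold lower number from compound 2 to compound 3 (0.30 log units; within the scatter). Within this pair, then, the effect does not depend on that donor. No outside measurement offers an explanation for this result.

Still open, going by these compounds, is how this position responds to a ring-bearing group such as morpholine or to a longer chain such as dibutylamino. Compound 1 differs from compound 3 in more than one place, so the role of its second ring fluorine also stays unresolved.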